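A few compounds are considered here, and "the series" means these few. Any claim that something is new, unique, unknown or untested is made for them only; others in the source may bear on it.

Measured in a functional assay on the whole organism (trachea) for inhibition, with Cavia porcellus as the target; a lower number here means that less compound is needed, a higher number that more compound is needed for the effect:
- compound 1 `CCOC(=O)CC(=O)N1CCSC1COc1ccccc1OC`: 11 mg/kg
- compound 2 `O=C(O)[C@@H]1CSC(CCc2ccccc2O)N1`: 45 mg/kg
- compound 3 `O=C(Cn1ccnc1)N1CCSC1COc1ccccc1O`: 27 mg/kg

Compound 1 stands lowest of the three numbers in this assay, so it is the one of which least is needed. Compound 3 lies nearest to it, yet beyond the scatter, and compound 2 lies furthest from it, also beyond the scatter. For the measured compounds named here, compound 2 and compound 3 themselves differ from each other in more than one place, so only their two values can be set side by side, and no step between them is counted here.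

Compound 4 `COc1ccccc1OCC1SCCN1C(=O)CC(C)=O` has not yet been measured. It differs from compound 1 in one place: methyl in place of ethoxy on a carbonyl carbon. Going by the values given here, nothing among the measured compounds shows this change in isolation, so no counted step can be leaned on. The rest of the molecule, the shared core of compound 1 with its side chain and aromatic portion, is kept unchanged. The change is small in count and sits on the acyl group away from the core; the expectation for compound 4 is therefore a step from compound 1 of no size beyond the scatter, if anything towards a slightly higher number, as a 1.4-fold higher number from compound 1 to compound 4 (0.13 log units; within the scatter). Compound 4 is estimated to give 15 mg/kg in this assay, within a range from 6 mg/kg to 40 mg/kg.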

Compound 4, dose for half-maximal effect: 26 mg/kg
Beside the measured number, compound 4's estimate is 1.7-fold (0.24 log units) below it; measured number inside the range.
By their numbers in this assay, from the lowest: compound 1; then compounds 4, 3 and 2 (each within the scatter of the next).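

In this assay, for the compounds shown here, methyl in place of ethoxy on a carbonyl carbon gives a 2.4-fold higher number from compound 1 to compound 4 (0.37 log units; beyond the scatter) and so provides the first single-place comparison. The step lies beyond the scatter, which shows that this end of the acyl group is not indifferent to change even with the shared core left untouched. The ethoxycarbonyl form needs less compound here than the acetyl form, but no measurement at hand speaks to the reason for this.

Still open, going by these compounds, is how a longer chain such as propoxy, an amine or a carboxylic acid in the same place would compare with ethoxy. A single step also cannot show whether this change would have a similar size on another member of the series.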